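From compound 1 to its chloro analogue, compound 4

The source may hold more compounds than are shown below. What is called first, only, known or untested is meant among the compounds shown, and "the series" means these compounds.

compound 1 `CCOC(=O)[C@@]1(C(=O)Nc2ccccc2)C[C@@H]1c1cc(OC)c(OC)c(OC)c1`: > 100000 nM (a limit)
compound 2 `CCOC(=O)[C@]1(C(=O)Nc2ccccc2)C[C@@H]1c1cc(OC)c(OC)c(OC)c1`: > 100000 nM (a limit)
compound 3 `CCOC(=O)C1(C(=O)Nc2ccccc2Cl)CC1c1cc(OC)c(OC)c(OC)c1`: 22100 nM; 76400 nM (2 entries)

In a functional assay on HeLa cells (Homo sapiens) for cytotoxicity, read by MTT assay, with a stated time of 48 h (a higher number here means a weaker inhibitor, a lower number a stronger inhibitor), compound 1 gives only a limit, > 100000 nM. Compound 2 also gives only a limit, > 100000 nM. Within the data shown here, the one measured step is a step that the two limits leave unreadable from compound 1 to compound 2, so it gives no size to build on. Compound 4 `CCOC(=O)[C@@]1(C(=O)Nc2ccccc2Cl)C[C@@H]1c1cc(OC)c(OC)c(OC)c1` keeps the configuration drawn for compound 1 and carries one change: chloro in place of hydrogen on an aromatic carbon, ortho to a large group. Compound 3 has the same (2-chlorophenyl)carbamoyl group with no configuration drawn, and it gives numbers in this assay, 22100 nM; 76400 nM (2 entries). On that basis a modest move towards stronger inhibition is expected, as an at least 2.2-fold lower number from compound 1 to compound 4 (0.34 log units; beyond the scatter). For compound 4 the estimated value is 45000 nM, with an expected range of 15000 nM to 100000 nM.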

Compound 4, half-maximal inhibitory concentration: > 100000 nM
Compound 4 was reported as a limit (the forecaster's own chance of this, stated with the estimate: 30%); at least 2.2-fold (0.34 log units) between middle value and limit.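

In this assay, among these compounds, compound 1 and compound 4 are both reported only as limits, so no step between them can be read. The compounds shown leave open which configuration lies behind the measured numbers of compound 3.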